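Swapping the amine-bearing chain for an oxan-4-yl ring

The source may report more compounds than this note shows. Statements on the series, on what has been measured and on what is new or still open speak of the compounds shown alone.

Among the measured compounds shown here, compound 2 `CN(C)CCCNc1nc(N)nc2cc(-c3ccc(C(F)(F)F)cc3)sc12` gives 148 ug/mL in a physicochemical assay for solubility, in phosphate buffer, at pH 6.5 (a higher number here means a more soluble compound, a lower number a less soluble compound), the lowest of the two numbers so far; compound 1 `CNc1nc(NCCCN(C)C)c2sc(-c3ccc(C(F)(F)F)cc3)cc2n1` gives 177 ug/mL, and the step of a 1.2-fold lower number from compound 1 to compound 2 (0.08 log units; within the scatter) lies within the scatter. Compound 3 `Nc1nc(NC2CCOCC2)c2sc(-c3ccc(C(F)(F)F)cc3)cc2n1` differs from compound 2 by oxan-4-yl in place of 3-(dimethylamino)propyl on a nitrogen on an aromatic ring. For the measured compounds named here, no measured step touches this position, and the one known step concerns a different nitrogen, so nothing here predicts the size directly. A downward step a 3.7-fold lower number from compound 2 to compound 3 (0.57 log units; beyond the scatter) is nonetheless expected for compound 3. The value of compound 3 in this assay is estimated at 40 ug/mL, within a range from 8 ug/mL to 150 ug/mL.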

Compound 3, solubility: < 5 ug/mL
Compound 3: a limit, no number; the forecaster's own chance of this, stated with the estimate: 10%; middle value at least 8.0-fold (0.90 log units) from the limit.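

The nitrogen on an aromatic ring that carries this group is a position where the read-out of this assay can move a long way: oxan-4-yl in place of 3-(dimethylamino)propyl gives an at least 29-fold lower number from compound 2 to compound 3 (1.47 log units; beyond the scatter). Among the compounds shown here, the only earlier step, at a different nitrogen, lay within the scatter. The value for compound 3 is a limit and not a number: the limit of < 5 ug/mL in this assay, at which 1 of the 3 values shown sits.

From the compounds shown here alone, how far compound 3 lies past its limit stays open, and so does the full size of the step. Also open, going by these compounds, is whether the dimethylamino nitrogen or the ring matters: a piperidin-4-yl ring or a 3-methoxypropyl chain could separate the two.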